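Solubility: anilino for the fused lactam on compound 1

The source may hold more compounds than are shown below. What is called first, only, known or untested is meant among the compounds shown, and "the series" means these compounds.

Compound 1 `O=C1c2ccccc2CN1c1cnc(NCc2c(F)ccc3c2CCO3)n2cnnc12` is tested in a physicochemical assay for solubility, read by LC-MS, in phosphate buffer, with a stated time of 24 h, at pH 7.4 (on this read-out lower numbers stand for lower solubility and higher numbers for higher solubility), where compound 1 gives 4000 nM, the lowest of the two plain numbers shown. Compound 3 `CN(c1ccn(C)n1)c1cnc(NCc2c(F)ccc3c2CCO3)c2cn[nH]c(=O)c12` gives 12000 nM in this assay, a higher number that lies beyond the scatter. Compound 2 `Cc1ncccc1-c1cnc(NCc2c(F)ccc3c2CCO3)c2cn[nH]c(=O)c12` returns only a limit in this assay, namely < 2000 nM (the limit of < 2000 nM in this assay, at which 1 of the 3 values shown sits).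

Going by the values given here, the single measured step is an at least 6.0-fold higher number from compound 2 to compound 3 (0.77 log units; beyond the scatter), a swap of the group on an aromatic carbon of a core that differs from the core of compound 1; it bears only loosely on what follows.

Compound 4 `Fc1ccc2c(c1CNc1ncc(Nc3ccccc3)c3nncn13)CCO2` differs from compound 1 by a group of 7 heavy atoms (6 carbon, 1 nitrogen; one six-membered aromatic ring of carbon only) in place of a group of 10 heavy atoms (8 carbon, 1 nitrogen, 1 oxygen; one five-membered non-aromatic ring with 1 hetero atom, one six-membered aromatic ring of carbon only), on an aromatic carbon. Among the compounds with values here, no measured step on the core of compound 1 addresses this position, and the loosely related step, an at least 6.0-fold higher number from compound 2 to compound 3 (0.77 log units; beyond the scatter), went upward. With so little to lean on, the step of a 1.3-fold higher number from compound 1 to compound 4 (0.10 log units; within the scatter) is expected to stay within the scatter, with a slight upward lean. Compound 4 is therefore estimated at 5000 nM, with a range from 1800 nM to 14000 nM in this assay.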

Compound 4, solubility: 3000 nM
The estimate for compound 4 lay 1.7-fold (0.22 log units) above the measured number; low and high end bracket the measured number.
By their numbers in this assay, from the lowest: compounds 4 and 1 (each within the scatter of the next); then compound 3. At a limit, below all of these: compound 2.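

In this assay, this position now has a direct reading on the core of compound 1: a 1.3-fold lower number from compound 1 to compound 4 (0.12 log units; within the scatter) is the step for anilino in place of the group of 10 heavy atoms. On this core, the two groups therefore cannot be told apart at this position, although the five-membered non-aromatic ring is lost and the entering anilino carries a hydrogen-bond donor that the leaving group lacks. The larger step, an at least 6.0-fold higher number from compound 2 to compound 3 (0.77 log units; beyond the scatter), stands on a different core and at a different group, so it cannot be carried over to this position.

Going by these compounds, whether an amine such as morpholino or a carboxylic acid at this position would move the number beyond the scatter on the core of compound 1 remains open. Nothing measured here explains the result.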